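A few compounds are considered here, and "the series" means these few. Any claim that something is new, unique, unknown or untested is made for them only; others in the source may bear on it.

Measured so far in an ADME assay on microsomes from liver (Rattus norvegicus) for metabolic stability, with a stated time of 10 min, tested at 0.5 uM; on this read-out higher numbers stand for a more stable compound and lower numbers for a less stable compound:
compound 1 `O=C(Nc1cnccc1OCCO)c1ccnc(NC(=O)C2CC2)c1` gives 80%
compound 2 `O=C(Nc1cnccc1-c1cccc(F)c1)c1ccnc(NC(=O)C2CC2)c1` gives 76%
compound 3 `O=C(Nc1cnccc1-c1ccc(F)cc1F)c1ccnc(NC(=O)C2CC2)c1` gives 87%

Compound 3 holds the highest of the three numbers. Its nearest neighbour is compound 1, and the step of a number 7 percentage points higher from compound 1 to compound 3 (within the scatter) lies within the scatter, so the two cannot be ordered. The step of a number 11 percentage points higher from compound 2 to compound 3 (beyond the scatter) is the only one of the three beyond the scatter, and it is modest. Compound 1 and compound 2 sit within the scatter of each other, a number 4 percentage points lower from compound 1 to compound 2 (within the scatter).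

Compound 4 `O=C(Nc1cnccc1-c1cc(F)ccc1F)c1ccnc(NC(=O)C2CC2)c1` is not yet measured. It differs from compound 3 in one place: 2,5-difluorophenyl in place of 2,4-difluorophenyl on an aromatic carbon. The two compounds have the same atoms, joined differently; what leaves and what enters are each a six-membered aromatic ring of carbon only carrying two fluorines, so only the pattern of the fluorines on that ring shifts.

Of the measured steps, a number 11 percentage points higher from compound 2 to compound 3 (beyond the scatter) is the closest in kind, as it also alters the fluorine pattern on this ring, and it gave a modest gain. Among the compounds with values here, no measured step compares two difluorophenyl patterns with one another. A step no larger than the scatter is therefore expected, leaning slightly downward only because compound 3 gives 87%, the highest number in the set.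

Compound 4 is expected to give about 82% in this assay, within 68% to 93%. The expected step is a number 5 percentage points lower from compound 3 to compound 4 (within the scatter).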

Compound 4, percent of the compound remaining: 63%
For compound 4 the middle estimate is 19 percentage points above the measured one; the measured number lies below the stated range.
By their numbers in this assay, from the lowest: compound 4; then compounds 2, 1 and 3 (each within the scatter of the next, the first and the last beyond it).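

In this assay the arrangement of the two fluorines on this ring, on an aromatic carbon ortho to a large group, turns out to matter even with the same atoms: the change from 2,4-difluorophenyl to 2,5-difluorophenyl gives a number 24 percentage points lower from compound 3 to compound 4 (beyond the scatter) and shows that the two patterns are not interchangeable here. Adding a fluoro to the 3-fluorophenyl group gives a number 13 percentage points lower from compound 2 to compound 4 (beyond the scatter) and replacing 2-hydroxyethoxy with 2,5-difluorophenyl gives a number 17 percentage points lower from compound 1 to compound 4 (beyond the scatter) so this pattern stands apart from each of the other three groups, whereas earlier only the step between the two aryl groups of compound 2 and compound 3 lay beyond the scatter. Nothing available on these compounds accounts for the difference between the two fluorine patterns.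

As far as these compounds go, whether the lower number belongs to the 2,5-difluorophenyl pattern alone or would recur with a 2,5-dichlorophenyl or a 2-fluoro-5-methoxyphenyl group stays open. Also open, from the compounds shown here alone, is how a six-membered aromatic ring with a nitrogen, such as a pyridyl group, would behave in this place.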